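The source may report more compounds than this note shows. Statements on the series, on what has been measured and on what is new or still open speak of the compounds shown alone.

Compound 1 `Nc1nc(N2CCN(C(=O)COc3ccc(Cl)cc3)CC2)c2nc(Cc3ccc(F)cc3)sc2n1`: 700 nM
Compound 2 `Nc1nc(N2CCN(C(=O)COc3ccc(Cl)cc3)CC2)c2nc(CCOc3ccc(F)cc3)sc2n1`: 3540 nM
Compound 3 `Nc1nc(N2CCN(C(=O)COc3ccc(Cl)cc3)CC2)c2nc(CCCc3ccc(F)cc3)sc2n1`: 960 nM

All three compounds share one core and differ only in the chain that carries a fluorinated ring. They were tested in a functional assay on cells (Lymphocyte, Homo sapiens); on this read-out higher numbers stand for weaker inhibition and lower numbers for stronger inhibition. Among the three numbers, compound 3 stands second highest. The gap to its nearest neighbour is a 1.4-fold higher number from compound 1 to compound 3 (0.14 log units; within the scatter), which lies within the scatter, so those two compounds cannot be told apart. The gap to the furthest number is a 3.7-fold lower number from compound 2 to compound 3 (0.57 log units; beyond the scatter), which lies beyond the scatter.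

The next compound, compound 4 `Nc1nc(N2CCN(C(=O)COc3ccc(Cl)cc3)CC2)c2nc(CCCCc3ccc(F)cc3)sc2n1`, has not yet been measured. It differs from compound 3 in one place: 4-fluorobenzyl in place of 4-fluorophenyl on a saturated chain carbon, three bonds along the chain from an aromatic carbon. The chain is thus extended by one more link.

Among the compounds with values here, two measured steps bear on this. The direct one is a 1.4-fold higher number from compound 1 to compound 3 (0.14 log units; within the scatter), where the chain grew by two links and the number stayed within the scatter. The other, a 5.1-fold higher number from compound 1 to compound 2 (0.70 log units; beyond the scatter), exchanged a chain link for an oxygen-bearing one and is less closely related. On this basis, no step beyond the scatter is expected in this assay; a slight rise in the number is the most likely direction. Compound 4 is therefore expected to give about 1300 nM, within the range 500 nM to 3500 nM, corresponding to an expected step of a 1.4-fold higher number from compound 3 to compound 4 (0.13 log units; within the scatter).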

Compound 4, half-maximal inhibitory concentration: 920 nM
Compound 4: the middle estimate sits 1.4-fold (0.15 log units) above what was measured; low and high end bracket the measured number.
By their numbers in this assay, from the lowest: compounds 1, 4 and 3 (each within the scatter of the next); then compound 2.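

In this assay, adding one more link to the chain gives a 1.0-fold lower number from compound 3 to compound 4 (0.02 log units; within the scatter) and setting this longest chain, 4-(4-fluorophenyl)butyl, against the shortest, 4-fluorobenzyl, gives a 1.3-fold higher number from compound 1 to compound 4 (0.12 log units; within the scatter) so compounds 1, 3 and 4 cannot be told apart by chain length. Before this result, that flat picture rested on a single pair of all-carbon chains; it now holds across three lengths, and the distance from the shared core to the fluorinated ring makes no readable difference within these compounds. Compound 2 goes against this picture: exchanging its 4-fluorophenoxy for 2-(4-fluorophenyl)ethyl gives a 3.8-fold lower number from compound 2 to compound 4 (0.59 log units; beyond the scatter) and so the chain with the oxygen remains the only one that stands apart from the all-carbon chains.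

As far as these compounds go, it remains open whether a still longer chain, such as 5-(4-fluorophenyl)pentyl, or a chain carrying an amine, would stay in the same range. No measurement at hand explains either the level numbers of the all-carbon chains or the gap to compound 2.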